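Ortho-dichlorobenzyl variant of an oxadiazole sulfonamide EP1 ligand

A few compounds are considered here, and "the series" means these few. Any claim that something is new, unique, unknown or untested is made for them only; others in the source may bear on it.

Measured compounds:
compound 1 `CCOc1ccc(Cc2nnc(CN(c3cccc(Cl)c3C)S(=O)(=O)c3ccc(C)cc3)o2)cc1`: 3.98 nM
compound 2 `Cc1ccc(S(=O)(=O)N(Cc2nnc(Cc3cccc(F)c3)o2)c2cccc(Cl)c2C)cc1`: 316 nM

Both compounds were tested in an assay on CHO cells for displacement of a labelled ligand from prostaglandin E2 receptor EP1 subtype (Homo sapiens); on this read-out higher numbers stand for weaker inhibition and lower numbers for stronger inhibition. Compound 2 gives the higher of the two numbers, and its nearest neighbour is compound 1, separated by a step that is well beyond the scatter.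

Compound 3 `Cc1ccc(S(=O)(=O)N(Cc2nnc(Cc3c(Cl)cccc3Cl)o2)c2cccc(Cl)c2C)cc1` has not been measured. It differs from compound 2 in one place: 2,6-dichlorophenyl in place of 3-fluorophenyl on a saturated chain carbon bound to an aromatic carbon.

For the measured compounds named here, only one measured step is available for comparison. It changed the same benzyl aryl group, and it was large: a 79-fold higher number from compound 1 to compound 2 (1.90 log units; beyond the scatter). That step shows that the identity of this aryl group can move the number a long way in this assay, but neither measured compound carries chlorine on that ring, so the direction for compound 3 is not indicated by the data. The step from compound 2 to compound 3 is therefore expected to be a 2.1-fold lower number from compound 2 to compound 3 (0.32 log units; beyond the scatter), with wide uncertainty in both directions. Compound 3 is estimated at 150 nM, within a range from 20 nM to 1500 nM.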

Compound 3, half-maximal inhibitory concentration: 63.1 nM
Beside the measured number, compound 3's estimate is 2.4-fold (0.38 log units) above it, and the stated range covers the measured number.
By their numbers in this assay, from the lowest: compound 1; then compound 3; then compound 2.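

In this assay, the 2,6-dichlorophenyl group gave a 5.0-fold lower number from compound 2 to compound 3 (0.70 log units; beyond the scatter), the first measured case of chlorine on this ring, showing that 3-fluorophenyl is not the floor for a group without the ethoxy substituent at this saturated chain carbon. The 4-ethoxyphenyl group nevertheless remains clearly ahead, with a 16-fold higher number from compound 1 to compound 3 (1.20 log units; beyond the scatter), so the change to 2,6-dichlorophenyl recovers only part of the distance opened by the earlier step and places compound 3 between the other two compounds. Nothing available explains why the number moves with these groups at this position.

The three compounds leave open whether both chlorines are needed, since a phenyl ring carrying a single chlorine, or an unsubstituted phenyl, would be required to separate their contributions from that of the ring itself. They also leave open whether the low number of compound 1 is specific to ethoxy or would persist with a methoxy group or a longer alkoxy chain on the ring.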